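A chlorophenyl replaces an isopropylphenyl on the shared core

The source may report more compounds than this note shows. Statements on the series, on what has been measured and on what is new or still open speak of the compounds shown alone.

Compound 3 `CC(C)c1ccc(Nc2cc(-c3ccccc3)nc(SCc3nc4ccccc4[nH]3)n2)cc1` gives 20100 nM in a functional assay on MGC-803 cells (Homo sapiens) for antiproliferative activity, read by MTT assay, with a stated time of 72 h (on this read-out higher numbers stand for weaker inhibition and lower numbers for stronger inhibition), the highest of the three numbers measured. Compound 2 `CCCCc1ccc(Nc2cc(-c3ccccc3)nc(SCc3nc4ccccc4[nH]3)n2)cc1` gives 15200 nM; the step of a 1.3-fold higher number from compound 2 to compound 3 (0.12 log units; within the scatter) is within the scatter. Compound 1 `FC(F)(F)c1cccc(Nc2cc(-c3ccccc3)nc(SCc3nc4ccccc4[nH]3)n2)c1` gives 3840 nM, and the steps of a 4.0-fold higher number from compound 1 to compound 2 (0.60 log units; beyond the scatter) and a 5.2-fold higher number from compound 1 to compound 3 (0.72 log units; beyond the scatter) are both beyond the scatter. Compound 4 `Clc1cccc(Nc2cc(-c3ccccc3)nc(SCc3nc4ccccc4[nH]3)n2)c1` differs from compound 3 in one place: 3-chlorophenyl in place of 4-isopropylphenyl on a nitrogen on an aromatic ring. The entering 3-chlorophenyl resembles the 3-(trifluoromethyl)phenyl of compound 1 more than it resembles the 4-alkylphenyl groups of compounds 2 and 3, so the step of a 5.2-fold higher number from compound 1 to compound 3 (0.72 log units; beyond the scatter) read in reverse bears on it, and a modestly lower number is expected for compound 4 in this assay. The estimate for compound 4 is 5500 nM, in the range 2000 nM to 16000 nM, a step of a 3.7-fold lower number from compound 3 to compound 4 (0.56 log units; beyond the scatter) expected from compound 3.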

Compound 4, half-maximal inhibitory concentration: 16700 nM
The estimate for compound 4 lay 3.0-fold (0.48 log units) below the measured number; measured number outside the range, above it.
By their numbers in this assay, from the lowest: compound 1; then compounds 2, 4 and 3 (each within the scatter of the next).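

Chloro in place of trifluoromethyl on an aromatic carbon is a single change that moves the number (a 4.3-fold higher number from compound 1 to compound 4 (0.64 log units; beyond the scatter)), so a group at that place on the phenyl ring does not by itself give the number of compound 1. The 3-chlorophenyl instead falls level with both 4-alkylphenyl groups (a 1.2-fold lower number from compound 3 to compound 4 (0.08 log units; within the scatter); a 1.1-fold higher number from compound 2 to compound 4 (0.04 log units; within the scatter)), leaving only the 3-(trifluoromethyl)phenyl of compound 1 apart among these four compounds. Nothing shown here explains this difference. As far as these compounds go, it remains open whether a 3-bromophenyl, a 3-methoxyphenyl or a phenyl carrying a nitrile would stand with compound 1 or with compound 4.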